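The source may report more compounds than this note shows. Statements on the series, on what has been measured and on what is new or still open speak of the compounds shown alone.

Within the data shown here, in a functional assay on MCF7 cells (Homo sapiens) for antiproliferative activity, read by MTT assay, with a stated time of 72 h (a lower number here means a stronger inhibitor, a higher number a weaker inhibitor), compound 2 `COc1cc(-n2cnc3ccc(-c4cccc([N+](=O)[O-])c4)cc32)cc(OC)c1OC` gives 4560 nM as the higher of the two numbers so far, while compound 1 `COc1ccc(-c2ccc3ncn(-c4cc(OC)c(OC)c(OC)c4)c3c2)cc1F` with 520 nM stands lower. The change to compound 3 `COc1cccc(-c2ccc3ncn(-c4cc(OC)c(OC)c(OC)c4)c3c2)c1` is methoxy in place of nitro on an aromatic carbon and amounts to methoxy in place of nitro on an aromatic carbon. Among the measured compounds shown here, only one measured step bears on it, the modest 8.8-fold higher number from compound 1 to compound 2 (0.94 log units; beyond the scatter) on going to 3-nitrophenyl from 3-fluoro-4-methoxyphenyl. Compound 3 also lacks the nitro, so a somewhat smaller move to a lower number is expected in this assay here. The estimate is a 3.5-fold lower number from compound 2 to compound 3 (0.55 log units; beyond the scatter) for this change. Compound 3 is expected at 1300 nM within an estimated range from 400 nM to 4000 nM overall.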

Compound 3, half-maximal inhibitory concentration: 1610 nM
The estimate for compound 3 lay 1.2-fold (0.09 log units) below the measured number; the measured number falls inside the stated range.
By their numbers in this assay, from the lowest: compound 1; then compound 3; then compound 2.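

In this assay, methoxy in place of nitro on this aromatic carbon gives a 2.8-fold lower number from compound 2 to compound 3 (0.45 log units; beyond the scatter), so this position responds to the group alone, with the rest of the molecule unchanged. Methoxy does not close the whole gap, however: 3-methoxyphenyl in place of 3-fluoro-4-methoxyphenyl gives a 3.1-fold higher number from compound 1 to compound 3 (0.49 log units; beyond the scatter), leaving compound 1 the lowest of the three. Nothing measured here explains either step. The compounds shown leave open which part of the 3-fluoro-4-methoxyphenyl group accounts for that gap, and how an amine or a hydroxyl group would read at this position.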